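The source may report more compounds than this note shows. Statements on the series, on what has been measured and on what is new or still open speak of the compounds shown alone.

Compound 1 `N#C/C(=C\c1c[nH]c2cc(F)ccc12)C(=O)c1c[nH]c2cc(F)ccc12`: > 50000 nM
Compound 2 `N#C/C(=C\c1c[nH]c2cc(F)ccc12)C(=O)c1c[nH]c2ccccc12`: 31600 nM

For the measured compounds named here, in a functional assay on MIA PaCa-2 cells (Homo sapiens) for cytotoxicity, read by WST assay, with a stated time of 48 h (a lower number here means a stronger inhibitor, a higher number a weaker inhibitor), compound 2 gives 31600 nM, the only actual number so far. For compound 1, the result of > 50000 nM is a limit. Compound 3 `COc1ccc2[nH]cc(C(=O)/C(C#N)=C/c3c[nH]c4cc(F)ccc34)c2c1` differs from compound 2 by methoxy in place of hydrogen on an aromatic carbon. Going by the values given here, the sole measured step, an at least 1.5-fold lower number from compound 1 to compound 2 (0.19 log units; that floor lies within the scatter), involves fluoro rather than methoxy, so it bears only loosely, and it gives no ground for expecting a large move in either direction. Also relevant is the limit of > 50000 nM in this assay, at which 1 of the 2 values shown sits. The estimated 1.3-fold lower number from compound 2 to compound 3 (0.10 log units; within the scatter) is expected to stay within the scatter. For compound 3, the expected value is 25000 nM, with an estimated range of 6000 nM to 50000 nM.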

Compound 3, half-maximal inhibitory concentration: > 50000 nM
Compound 3 gave a limit, no number (the forecaster's own chance of this, stated with the estimate: 35%); middle value at least 2.0-fold (0.30 log units) away from the limit.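

In this assay, methoxy in place of hydrogen on this aromatic carbon of the six-membered aromatic ring gives an at least 1.5-fold higher number from compound 2 to compound 3 (0.19 log units; that floor lies within the scatter). Going by these compounds, compound 3 stands at > 50000 nM, which is a limit and not a number, so this change shows no gain at this position, and the true size of the step stays unknown. Compound 2 remains the only compound with an actual number: the limit of > 50000 nM in this assay, at which 2 of the 3 values shown sit.

On these data alone, whether a smaller or differently built group, such as an amine or a carboxylic acid, would lower the number at this position remains open. Also open, as far as these compounds go, is how a methoxy group would read out on a core that gives a measurable value.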